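From sec-Butyl to Butyl on an Amine Nitrogen

The source may hold more compounds than are shown below. What is called first, only, known or untested is meant among the compounds shown, and "the series" means these compounds.

Compound 1 `CCC(C)NC(=C\C(=O)/C=C/c1ccc(O)c(OC)c1)/C=C/c1ccc(O)c(OC)c1` has been tested in a functional assay on CHO-K1 cells (Cricetulus griseus) for inhibition, read by MTT assay, with a stated time of 72 h; on this read-out lower numbers stand for stronger inhibition and higher numbers for weaker inhibition. There, compound 1 gives > 25000 nM, which is a limit of the assay and not a number. Compound 2 `CC(=O)Oc1ccc(/C=C/C(=O)/C=C(/C=C/c2ccc(OC(C)=O)cc2)NCC(C)C)cc1` gives > 25000 nM, which is also a limit. The data so far therefore amount to the limit of > 25000 nM in this assay, at which 2 of the 2 values shown sit.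

Compound 3 `CCCCNC(=C\C(=O)/C=C/c1ccc(O)c(OC)c1)/C=C/c1ccc(O)c(OC)c1` keeps the core of compound 1 and has butyl in place of sec-butyl on an amine nitrogen. Going by the values given here, no measured pair shows what this swap does. The expectation is therefore no step beyond the usual scatter in this assay, in either direction, since compound 1 stands at the limit of > 25000 nM. The expected step that the limit leaves unreadable from compound 1 to compound 3 is correspondingly small. Compound 3 is estimated at 28000 nM, with an expected range from 12000 nM to 60000 nM.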

Compound 3, half-maximal inhibitory concentration: 7000 nM
For compound 3 the middle estimate is 4.0-fold (0.60 log units) above the measured one; the measured number lies below the stated range.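

Joining the same atoms differently on the amine nitrogen, with butyl in place of sec-butyl, gives an at least 3.5-fold lower number from compound 1 to compound 3 (0.55 log units; beyond the scatter) in this assay, and a lower number here stands for stronger inhibition. This shows that the read-out responds to how the chain on this nitrogen is joined, even though the swap leaves the atoms themselves and the rest of compound 1 unchanged. Compound 3 thereby gives the series its first value that is a number and not a limit: the limit of > 25000 nM in this assay, at which 2 of the 3 values shown sit.

This is a single pair on a single core, so it cannot show whether the same swap would act alike on another core. It also leaves open whether a longer chain such as hexyl, a shorter one such as propyl, or a ring such as cyclohexyl on this nitrogen would lower the number further.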